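The compounds below may be only part of what the source reports. "The series", "measured", "known", "first", "only" and "open" are said of these compounds alone.

In a functional assay on HeLa cells (Homo sapiens) for antiproliferative activity, read by MTT assay, with a stated time of 24 h (on this read-out lower numbers stand for stronger inhibition and higher numbers for weaker inhibition), two compounds have been measured so far. Compound 1 `O=S(=O)(c1ccc(C(F)(F)F)cc1)n1c(-c2cn(-c3ccccc3)nc2-c2ccc(F)cc2)nc2ccccc21` gives 1430 nM. Compound 2 `O=S(=O)(c1ccc(Cl)cc1)n1c(-c2cn(-c3ccccc3)nc2-c2ccc(C(F)(F)F)cc2)nc2ccccc21` gives 3060 nM, the higher of the two numbers and therefore the weaker inhibition, and its gap to compound 1 lies beyond the usual scatter.

Compound 3 `O=S(=O)(c1ccc(C(F)(F)F)cc1)n1c(-c2cn(-c3ccccc3)nc2-c2ccc(C(F)(F)F)cc2)nc2ccccc21` has not yet been measured. It departs from compound 2 in one place: trifluoromethyl in place of chloro on an aromatic carbon. Trifluoromethyl stands in place of chloro on an aromatic carbon, which turns 4-chlorophenyl into 4-(trifluoromethyl)phenyl. Among the measured compounds shown here, no measured pair isolates this change, so the data give no direct guide to its size. The only indirect hint is that compound 1, which carries the 4-(trifluoromethyl)phenyl group and also differs elsewhere, gives 1430 nM. On that slender basis, a small move towards a lower number is expected in this assay, one that stays within the scatter. The expected size of the change is a 1.4-fold lower number from compound 2 to compound 3 (0.14 log units; within the scatter). The estimated value for compound 3 is 2200 nM, with an expected range of 1000 nM to 4800 nM.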

Compound 3, half-maximal inhibitory concentration: 970 nM
For compound 3 the middle estimate is 2.3-fold (0.36 log units) above the measured one; the measured number lies below the stated range.
By their numbers in this assay, from the lowest: compounds 3 and 1 (each within the scatter of the next); then compound 2.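

In this assay, among the compounds shown here, the exchange of chloro for trifluoromethyl on an aromatic carbon, para to a large group, turns out to be a real effect, with a 3.2-fold lower number from compound 2 to compound 3 (0.50 log units; beyond the scatter); this is the first direct reading of that change, and it shows that activity at this position depends on which of the two groups is present. At the other substituted phenyl group, trifluoromethyl in place of fluoro gives a 1.5-fold lower number from compound 1 to compound 3 (0.17 log units; within the scatter), so that exchange has no effect that can be told from the scatter, and in these three compounds only the change from 4-chlorophenyl to 4-(trifluoromethyl)phenyl produces a clear step. The data offer no evidence on why the exchange at this position has the effect it does.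

On these data alone, it remains open how a methoxy group, an amine or a carboxylic acid would compare with trifluoromethyl and chloro at this position, and whether a bare phenyl group would fall on either side of them. Also open, as far as these compounds go, is whether the step seen here would keep its size if fluoro replaced the second trifluoromethyl group elsewhere on the molecule.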